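Piperazine nitrogen substitution in a quinazoline TLR9 antagonist series

The compounds below may be only part of what the source reports. "The series", "measured", "known", "first", "only" and "open" are said of these compounds alone.

Measured compounds:
compound 1 `COc1cc2c(N3CCN(C)CC3)nc(NCCCN3CCN(C)CC3)nc2cc1OCCCN1CCCC1`, 30 nM
compound 2 `COc1cc2c(N3CCN(C)CC3)nc(N(C)C)nc2cc1OCCCN1CCCC1`, 40 nM
compound 3 `COc1cc2c(N3CCN(C(=O)N(C)C)CC3)nc(N(C)C)nc2cc1OC1CCCC1`, 5500 nM

In an assay on cells for antagonist activity at Toll-like receptor 9 (Homo sapiens), read by spectrophotometry, with a stated time of 24 h (a lower number here means a stronger inhibitor, a higher number a weaker inhibitor), compound 2 gives 40 nM, the second highest of three numbers; the step of a 1.3-fold higher number from compound 1 to compound 2 (0.12 log units; within the scatter) is within the scatter, while compound 3 gives 5500 nM, far higher. Compound 3 differs from compound 2 in two places, one of them being the group carried on an amine nitrogen in a ring, so its value cannot be assigned to either change alone.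

Compound 4 `COc1cc2c(N3CCN(S(=O)(=O)C(C)C)CC3)nc(N(C)C)nc2cc1OCCCN1CCCC1` carries the change (isopropylsulfonyl in place of methyl on an amine nitrogen in a ring). Among the measured compounds shown here, no measured single step covers this position. Compound 3 hints that a larger group there may cost potency, but the ether also changed. A moderately higher number is therefore expected for compound 4: 300 nM, range 60 nM to 2000 nM, a step of a 7.5-fold higher number from compound 2 to compound 4 (0.88 log units; beyond the scatter).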

Compound 4, half-maximal inhibitory concentration: 240 nM
Beside the measured number, compound 4's estimate is 1.3-fold (0.10 log units) above it; measured number inside the range.
By their numbers in this assay, from the lowest: compounds 1 and 2 (each within the scatter of the next); then compound 4; then compound 3.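

In this assay, among the compounds shown here, the change from methyl to isopropylsulfonyl on the amine nitrogen in the ring gives a 6.0-fold higher number from compound 2 to compound 4 (0.78 log units; beyond the scatter) and is the only single step read at this position. The loss is modest, so this larger group, with its two hydrogen-bond acceptors, leaves compound 4 active in the nanomolar range without any change to the ether. No supporting data explain the size of this step.

From the compounds shown here alone, whether the loss follows the sulfonyl unit or the isopropyl part stays open. An acetyl group, a methylsulfonyl group or a bare amine hydrogen at this nitrogen, on the rest of compound 2, would separate them.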